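Same Compound, Drawn Without a Double-Bond Configuration

A few compounds are considered here, and "the series" means these few. Any claim that something is new, unique, unknown or untested is made for them only; others in the source may bear on it.

Measured compounds:
Compound 1 `CC(=NNC(=S)Nc1ccccc1)c1ccccn1`: 0.18 nM
Compound 2 `C/C(=N/NC(=S)Nc1ccc([N+](=O)[O-])cc1)c1ccccn1`: 52 nM

In a functional assay on MCF7 cells (Homo sapiens) for cytotoxicity, read by MTT assay, with a stated time of 48 h (on this read-out lower numbers stand for stronger inhibition and higher numbers for weaker inhibition), compound 2 gives 52 nM, the higher of the two numbers shown. Compound 1 gives 0.18 nM in this assay, a far lower number, and the gap between the two lies well beyond the scatter of repeated measurements. Compound 3 `CC(=NNC(=S)Nc1ccc([N+](=O)[O-])cc1)c1ccccn1` is now to be tested in this assay. Its relation to compound 2 is unusual: the two compounds have the same atoms and bonds; at least one stereo element is drawn with a configuration in one of them and without one in the other: 1 of 1 stereo elements differ; a double bond is drawn Z in compound 2 and without a configuration in compound 3. Nothing enters and nothing leaves, so the two drawings describe the same substance, differing only in whether the double-bond geometry is written down. For that reason no step beyond the scatter is expected in either direction; the estimated step of no change at the digits printed from compound 2 to compound 3 (within the scatter) simply reflects repeat measurement of one material. Compound 3 is therefore expected to give about 52 nM, within a range of 22 nM to 125 nM.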

Compound 3, half-maximal inhibitory concentration: 52 nM
Beside the measured number, compound 3's estimate shows no gap at the digits printed; the range from low to high includes it.
By their numbers in this assay, from the lowest: compound 1; then compounds 2 and 3 (each within the scatter of the next).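

In this assay, writing the double-bond geometry down or leaving it out changes nothing that can be seen, with no change at the digits printed from compound 2 to compound 3 (within the scatter). The two entries can be read as one substance recorded twice, because the only difference between them is: the fact that one of compounds 2 and 3 is drawn with a defined configuration and the other without, at the place where they differ

This gives the earlier contrast a second reading, as nitro in place of hydrogen on an aromatic carbon again comes with a 290-fold higher number from compound 1 to compound 3 (2.46 log units; beyond the scatter).

On these data alone, only hydrogen and nitro appear on that aromatic carbon, and it remains open whether the large step is particular to nitro or would also appear with an amine or a methoxy group in the same place. Also open, as far as these compounds go, is whether the tested material holds a single double-bond geometry or a mixture of both.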